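The source may hold more compounds than are shown below. What is called first, only, known or untested is meant among the compounds shown, and "the series" means these compounds.

Compound 1 `O=C(/C=C/c1ccccc1)c1ccc(N2CCN(c3cccc(Cl)c3Cl)CC2)cc1` is the reference point of this series. In a functional assay on the whole organism (strain Kunming) for inhibition, with Mus musculus as the target, with a stated time of 1 h, at a dose of 40 mg/kg by the oral route (a higher number here means more inhibition at the dose given (going by the name of the read-out), a lower number less inhibition), compound 1 gives 30.7%, the highest of the three numbers recorded, and its separation from the other two lies beyond the scatter. Compound 2 `O=C(/C=C/c1ccc(Cl)cc1)c1ccc(N2CCN(c3cccc(Cl)c3)CC2)cc1` gives 5.85% in this assay, and compound 3 `COc1ccccc1N1CCN(c2ccc(C(=O)/C=C/c3ccc(Cl)cc3)cc2)CC1` gives 6.13%. Going by the values given here, the only single-point step among the measured compounds is a number 0.3 percentage points higher from compound 2 to compound 3 (within the scatter), which shows that exchanging one aryl group for another on the ring nitrogen left the read-out unchanged there.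

Compound 4 `Cc1ccc(S(=O)(=O)N2CCN(c3ccc(C(=O)/C=C/c4ccccc4)cc3)CC2)cc1` differs from compound 1 in one place: (4-methylphenyl)sulfonyl in place of 2,3-dichlorophenyl on an amine nitrogen in a ring. Among the compounds with values here, no measured step replaces an aryl group on that nitrogen with a sulfonyl group, so the aryl-for-aryl step from compound 2 to compound 3 bears on it only loosely and gives no direction. With compound 1 already the highest of the set, the author expects compound 4 to fall somewhat, by a number 14.7 percentage points lower from compound 1 to compound 4 (beyond the scatter), and estimates its inhibition at 16%, within a range from 2% to 34%.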

Compound 4, a percentage reported as inhibition, in the whole organism at one dose (the size of the read-out at that dose, not a potency): 30.8%
Estimate against measurement, compound 4: 14.8 percentage points below; the range from low to high includes it.
By their numbers in this assay, from the lowest: compounds 2 and 3 (each within the scatter of the next); then compounds 1 and 4 (each within the scatter of the next).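

At the ring nitrogen of the core of compound 1, the exchange of 2,3-dichlorophenyl for (4-methylphenyl)sulfonyl gives a number 0.1 percentage points higher from compound 1 to compound 4 (within the scatter) in this assay, so the two groups cannot be told apart in this read-out. The earlier step, a number 0.3 percentage points higher from compound 2 to compound 3 (within the scatter), only set one aryl group against another at low values, whereas this one shows that an aryl group joined directly to the nitrogen and one joined through a sulfonyl group read alike at the top of the series. Nothing available explains why these two groups read alike.

On these data alone, it remains open whether a benzoyl group or a simple alkyl chain on this nitrogen would read the same. As far as these compounds go, it is also open whether the (4-methylphenyl)sulfonyl group would match the aryl groups on the core of compound 2.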